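Saturated Chain in Place of Allyl on a Selenocyanate Carbamate

The source may report more compounds than this note shows. Statements on the series, on what has been measured and on what is new or still open speak of the compounds shown alone.

Three carbamates sharing one selenocyanate-bearing core have been tested in a functional assay on HTB-54 cells (Homo sapiens) for cytotoxicity, read by MTT assay, with a stated time of 72 h; a lower number here means a stronger inhibitor of growth, a higher number a weaker inhibitor of growth. Compound 1, `N#C[Se]c1ccc(NC(=O)OCc2ccc([N+](=O)[O-])cc2)cc1`, gives 22900 nM in this assay. Compound 2, `N#C[Se]c1ccc(NC(=O)Oc2ccc(F)cc2)cc1`, gives 25000 nM. Compound 3, `C=CCOC(=O)Nc1ccc([Se]C#N)cc1`, gives 27000 nM. Compound 3 sits alongside the other two, since its gaps to compound 2 and to compound 1 both fall within the usual scatter of repeated measurements, so the three numbers cannot be told apart.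

Compound 4, `CCCOC(=O)Nc1ccc([Se]C#N)cc1`, has not yet been measured. It differs from compound 3 in one place: ethyl in place of vinyl on a saturated chain carbon bound to an oxygen next to a carbonyl group. The change is allyl to propyl at the carbamate oxygen, with no ring and no donor or acceptor gained or lost.

Because compound 3 gives 27000 nM in this assay and the other two measured numbers cannot be told apart from it, and the exchange of vinyl for ethyl is small, compound 4 is expected to show no step beyond the scatter, so the expected step of no change at the digits printed from compound 3 to compound 4 (within the scatter) is essentially flat. Compound 4 is thus estimated at 27000 nM, with a range from 13000 nM to 54000 nM.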

Compound 4, concentration for 50% growth inhibition: 28900 nM
The estimate for compound 4 lay 1.1-fold (0.03 log units) below the measured number, within the range that was stated.
By their numbers in this assay, from the lowest: compounds 1, 2, 3 and 4 (each within the scatter of the next).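

In this assay, within the data shown here, ethyl in place of vinyl on a saturated chain carbon bound to an oxygen next to a carbonyl group gives a 1.1-fold higher number from compound 3 to compound 4 (0.03 log units; within the scatter), the first step in this set between two compounds that differ in one place. Compound 4 lacks the double bond outside aromatic rings that compound 3 carries, yet the two cannot be told apart, so at this position that double bond makes no difference that this assay can resolve. No evidence is available that bears on why the exchange leaves the number in place.

From the compounds shown here alone, whether a longer chain, a branched chain such as isopropyl, or a terminal amine at this position would move the number beyond the scatter remains open. So does whether a carboxylic acid there would do so.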